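The source may hold more compounds than are shown below. What is called first, only, known or untested is meant among the compounds shown, and "the series" means these compounds.

Measured so far in a functional assay on A-375 cells (Homo sapiens) for antiproliferative activity; on this read-out higher numbers stand for weaker inhibition and lower numbers for stronger inhibition:
compound 1, `CCO/N=C/c1c(N)ncnc1Oc1ccc2[nH]c(C)cc2c1F`: 27 nM
compound 2, `COCCCO/N=C/c1c(N)ncnc1Oc1ccc2[nH]c(C)cc2c1F`: 300 nM
compound 3, `CO/N=C/c1c(N)ncnc1Oc1ccc2ncccc2c1`: 1830 nM

Compound 2 holds the second highest of the three numbers. Compound 3 is nearest to it, with a higher number in this assay; compound 1 is furthest, with a lower one.

Compound 4, `Cc1cc2c(F)c(Oc3ncnc(N)c3/C=N/OCCO)ccc2[nH]1`, has not yet been measured in this assay. Against compound 2 the change is hydroxy in place of methoxymethyl on a saturated chain carbon, two bonds along the chain from an oxygen on an unsaturated carbon. Among the measured compounds shown here, one measured step bears on it: an 11-fold higher number from compound 1 to compound 2 (1.05 log units; beyond the scatter), where the methoxymethyl that compound 4 now loses had been put in place of hydrogen on a saturated chain carbon, two bonds along the chain from an oxygen on an unsaturated carbon. For the measured compounds named here, compound 4 undoes that addition but, in place of the hydrogen of compound 1, carries a hydroxy, and no measured pair shows what a hydroxy at this place does. With the methoxymethyl gone, the step is expected to run back toward compound 1, so a clearly lower number than that of compound 2 is expected for compound 4, a 5.0-fold lower number from compound 2 to compound 4 (0.70 log units; beyond the scatter), with the hydroxy kept as an open question.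

Compound 4 is therefore estimated at 60 nM, within a range of 20 nM to 200 nM.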

Compound 4, half-maximal inhibitory concentration: 372 nM
Estimate against measurement, compound 4: 6.2-fold (0.79 log units) below; measured number above the stated range.
By their numbers in this assay, from the lowest: compound 1; then compounds 2 and 4 (each within the scatter of the next); then compound 3.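

In this assay, hydroxy in place of methoxymethyl on this saturated chain carbon gives a 1.2-fold higher number from compound 2 to compound 4 (0.09 log units; within the scatter) and so leaves the read-out where compound 2 had it: removing the methoxymethyl does not by itself return the number toward that of compound 1. Hydroxy in place of hydrogen on the same carbon gives a 14-fold higher number from compound 1 to compound 4 (1.14 log units; beyond the scatter) and so costs as much as the methoxymethyl did in an 11-fold higher number from compound 1 to compound 2 (1.05 log units; beyond the scatter) and shows that two groups differing in size and in hydrogen-bond donors, the hydroxy with one and the methoxymethyl with none, go with the same outcome here, while the hydrogen of compound 1 stands apart from both. No measurement of any property is at hand that would account for this result.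

Among the compounds shown here, with only two groups set against hydrogen at this carbon, it remains open whether any group placed there goes with a higher number or only these two do. A methyl, a fluorine, an amine or a carboxylic acid on this carbon, or a longer chain ending in hydroxy, would show how far that holds.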